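This account rests on a few compounds, and the source may have more. Where it says the series, first, only, none or still open, it means among the compounds named here.

The series shares the core shown for compound 1 `C=CC1=C(C(=O)NCC(C)C)C(c2ccc(Cl)c(Cl)c2)OC1`. In a functional assay on HeLa cells (Homo sapiens) for cytotoxicity, read by MTT assay, with a stated time of 24 h (on this read-out higher numbers stand for weaker inhibition and lower numbers for stronger inhibition), compound 1 gives 60100 nM, the highest of the two numbers reported; the nearest number belongs to compound 3 `C=CC1=C(C(=O)NC2CCCCC2)C(c2ccc(OC)c(OC)c2)OC1`, which in this assay gives 5540 nM, a gap beyond the scatter. Compound 2 `C=CC1=C(C(=O)Nc2ccccc2OC)C(c2ccc(Cl)c(Cl)c2)OC1` in this assay reaches only a limit of > 100000 nM. For the measured compounds named here, the one single-point step among the measured compounds is an at least 1.6-fold higher number from compound 1 to compound 2 (0.22 log units; that floor lies within the scatter), and that reading rests on the limit of > 100000 nM in this assay, at which 1 of the 3 values shown sits, rather than on a number.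

Compound 4 `C=CC1=C(C(=O)O)C(c2ccc(Cl)c(Cl)c2)OC1` differs from compound 1 by hydroxy in place of isobutylamino on a carbonyl carbon. Going by the values given here, neither measured comparison touches this change: the step from compound 1 to compound 2 exchanges one group on the amide-type nitrogen for another, while compound 3 differs from compound 1 in two places at once and gives no step. Nothing measured bears on removing the amide-type nitrogen altogether, so the expected step of a 1.5-fold higher number from compound 1 to compound 4 (0.18 log units; within the scatter) is anchored only by the weak end of the series. Compound 4 is estimated at 90000 nM in this assay, with a range from 30000 nM to 300000 nM, and a limit reading is expected to be about as likely as a number.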

Compound 4, half-maximal inhibitory concentration: 10300 nM
Beside the measured number, compound 4's estimate is 8.7-fold (0.94 log units) above it; measured number outside the range, below it.
By their numbers in this assay, from the lowest: compounds 3 and 4 (each within the scatter of the next); then compound 1. At a limit, above all of these: compound 2.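

For the compounds shown here, the new step, a 5.8-fold lower number from compound 1 to compound 4 (0.77 log units; beyond the scatter) in this assay, is the first reading at this carbonyl carbon with a number on both sides. It shows that the isobutylamino group, with its 5 heavy atoms, can give way to hydroxy, with 1 heavy atom, and the number goes down rather than up. The series therefore does not depend on the amide-type nitrogen for a measurable read-out in this cell assay, at least for the pair compound 1 and compound 4.

Still open, going by these compounds, is whether a methyl ester or an unsubstituted amide on the same carbonyl carbon reads like the carboxy group or like the isobutylcarbamoyl group. The effect of the group on the amide-type nitrogen also stays unsettled, as compound 2 is a limit and not a number: the limit of > 100000 nM in this assay, at which 1 of the 4 values shown sits.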